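Swapping the Acetyl Group of Compound 1

The source may report more compounds than this note shows. Statements on the series, on what has been measured and on what is new or still open speak of the compounds shown alone.

Compound 1 `CC(=O)c1ccccc1OCc1ccc2c(c1)=[N+]([O-])C(C)(C)[N+]=2[O-]` is the starting point here. In an ADME assay on cells (Erythrocyte, Homo sapiens), read by spectrophotometry and hemolysis, with a stated time of 24 h (on this read-out higher numbers stand for weaker inhibition and lower numbers for stronger inhibition), compound 1 gives < 50 uM, which is a limit of the assay and not an exact number. A second compound, compound 2 `[O-][n+]1onc2ccc(COc3ccc(/C=N/NC(=S)Nc4ccccc4)cc3)cc21`, gives "nd(insoluble)" (no result reported), so it adds no number to compare. The measured picture therefore comes down to the limit of < 50 uM in this assay, at which 1 of the 2 values shown sits.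

The next molecule is compound 3 `CC1(C)[N+]([O-])=c2ccc(COc3ccccc3/C=N\NC(N)=S)cc2=[N+]1[O-]`, which has not yet been measured. It keeps the core of compound 1 but exchanges the acetyl for a larger group on an aromatic carbon: a group of 6 heavy atoms (2 carbon, 3 nitrogen, 1 sulfur; no ring) in place of a group of 3 heavy atoms (2 carbon, 1 oxygen; no ring), on an aromatic carbon.

Among the compounds with values here, no pair of measured compounds shows what an exchange like this does, so the data set no size for the step. The working expectation in this assay is therefore a step no larger than the usual scatter, in neither direction. The estimated change is a step that the limit leaves unreadable from compound 1 to compound 3, and it is only rough, as it starts from a limit. For compound 3 the expected value is 30 uM, with an estimated range from 10 uM to 90 uM.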

Compound 3, concentration for 50% inhibition: > 200 uM
Compound 3 ended at the assay's limit (the forecaster's own chance of this, stated with the estimate: 50%); at least 6.6-fold (0.82 log units) between middle value and limit.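

Within the data shown here, this is the first readable step at this place, on an aromatic carbon of a six-membered aromatic ring of carbon only, ortho to a large group. In this assay, taking away the acetyl and putting in the larger open-chain group, which brings hydrogen-bond donors that the acetyl lacks, gives an at least 4.0-fold higher number from compound 1 to compound 3 (0.60 log units; beyond the scatter), so the exchange goes with weaker inhibition on this read-out and the position is not indifferent to what sits there. The gap rests on two limits of the assay rather than on two exact numbers, so it marks only the smallest possible step, and the true one may be larger: the limit of > 200 uM in this assay, at which 1 of the 3 values shown sits.

The compounds shown do not tell which part of the entering group goes with the change, whether its size, its sulfur or its hydrogen-bond donors, since all of these change together in one exchange. Among these compounds, a smaller group at the same place, such as a simple amine or a carboxylic acid, would show whether the read-out climbs gradually or only with a group like the one in compound 3.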